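Compound 3 and a further 2-aminoethyl group

The source may hold more compounds than are shown below. What is called first, only, known or untested is meant among the compounds shown, and "the series" means these compounds.

- Compound 1 `CC(C)=CCCC(C)=CCNCCNCCNCCNCCNCCN`: > 150000 nM, a limit of the assay
- Compound 2 `CC(C)=CCC/C(C)=C\CCC(C)=CCNCCN`: 32300 nM
- Compound 3 `CC(C)=CCC/C(C)=C\CCC(C)=CCNCCNCCNCCNCCN`: 43500 nM

In a toxicity assay on CHO cells (Cricetulus griseus) for cytotoxicity, read by WST assay, with a stated time of 24 h (on this read-out lower numbers stand for stronger inhibition and higher numbers for weaker inhibition), compound 3 stands at 43500 nM, level with compound 2 within the scatter. Compound 4 `CC(C)=CCC/C(C)=C\CCC(C)=CCNCCNCCNCCNCCNCCN` carries 2-aminoethyl in place of hydrogen on an amine nitrogen. Going by the values given here, one measured step bears on this change, as it lengthened the same chain: a 1.3-fold higher number from compound 2 to compound 3 (0.13 log units; within the scatter). That step stayed small, and compound 4 adds less than it did. No shift beyond the scatter is therefore expected, and the estimated step is a 1.1-fold higher number from compound 3 to compound 4 (0.06 log units; within the scatter). The estimate for compound 4 is 50000 nM, with an expected range of 25000 nM to 100000 nM.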

Compound 4, half-maximal inhibitory concentration: 41700 nM
Compound 4: the middle estimate sits 1.2-fold (0.08 log units) above what was measured, and the stated range covers the measured number.
By their numbers in this assay, from the lowest: compounds 2, 4 and 3 (each within the scatter of the next). At a limit, above all of these: compound 1.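

In this assay, 2-aminoethyl in place of hydrogen on this amine nitrogen gives a 1.0-fold lower number from compound 3 to compound 4 (0.02 log units; within the scatter), so this lengthening of the chain, like the one before it, stays within the scatter. By contrast, 3-methylbut-2-en-1-yl in place of hydrogen on a saturated chain carbon bound to a double-bonded chain carbon gives an at least 3.5-fold lower number from compound 1 to compound 4 (0.55 log units; beyond the scatter), a change beyond the scatter. The number for compound 1 is a limit of the assay: the limit of > 150000 nM in this assay, at which 1 of the 4 values shown sits.

The compounds shown leave open whether a still longer amine chain would stay level, and whether an acetyl group on this amine nitrogen would move the number.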